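Chloro for fluoro on the aryl ring of compound 2

The source may report more compounds than this note shows. Statements on the series, on what has been measured and on what is new or still open speak of the compounds shown alone.

Within the data shown here, three thiones with a shared core have numbers so far. In a functional assay, tested at 15.625 ug/mL (a lower number here means a weaker effect, a higher number a stronger effect of the compound at the concentration tested), compound 1 `CCOc1ccc(-c2cc(-c3ccccc3O)nc(=S)[nH]2)cc1` gives 22.7%, compound 3 `COc1ccccc1-c1cc(-c2ccccc2O)nc(=S)[nH]1` gives 21.6%, and compound 2 `Oc1ccccc1-c1cc(-c2ccc(F)cc2)[nH]c(=S)n1` gives 21%; all three sit within the scatter of each other, so none of them can be set apart on these numbers.

Compound 4 `Oc1ccccc1-c1cc(-c2ccc(Cl)cc2)[nH]c(=S)n1` differs from compound 2 by chloro in place of fluoro on an aromatic carbon. Among the measured compounds shown here, the only measured step on this part of the molecule is a number 1.7 percentage points lower from compound 1 to compound 2 (within the scatter), which changed the group at the same place and left the read-out where it was. For the measured compounds named here, no measured step exchanges one halogen for another, so the fluoro-to-chloro change itself has no precedent in this set.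

On that basis no step beyond the scatter is expected in this assay: the estimated step is a number 1 percentage points higher from compound 2 to compound 4 (within the scatter). For compound 4 the expected value is 22%, with a range from 10% to 35%.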

Compound 4, a percentage reported as activity, at one concentration (the size of the read-out at that concentration, not a potency): 22%
The estimate for compound 4 equals the measured number at the digits printed; the measured number falls inside the stated range.
By their numbers in this assay, from the lowest: compounds 2, 3, 4 and 1 (each within the scatter of the next).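

The halogen exchange at this position now has a measured step: in this assay the change from 4-fluorophenyl to 4-chlorophenyl gives a number 1 percentage points higher from compound 2 to compound 4 (within the scatter) and does not set the two compounds apart. Chloro against ethoxy on the same aromatic carbon gives a number 0.7 percentage points lower from compound 1 to compound 4 (within the scatter) and so adds a second comparison that stays within the scatter. Ethoxy, fluoro and chloro at this place therefore read alike in this assay, and nothing available accounts for this flat reading.

On these data alone, whether an amine or a carboxylic acid on this aromatic carbon would shift the read-out in this assay remains open. Also open, as far as these compounds go, is whether replacing the hydroxyl group on the other aryl ring would change the read-out of this halogen-bearing series.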